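A few compounds are considered here, and "the series" means these few. Any claim that something is new, unique, unknown or untested is made for them only; others in the source may bear on it.

Compound 1 `O=S(=O)(Nc1ccc(-c2nc3ccccc3o2)cc1)c1ccc(Cl)s1` carries a sulfonamide that joins an aryl group to the shared core. In an assay on isolated protein for inhibition of malate dehydrogenase, mitochondrial (Sus scrofa), with stated times of 45 min and 30 min (a lower number here means a stronger inhibitor, a higher number a weaker inhibitor), compound 1 gives only a limit of the assay, > 63000 nM, and not a measured number. A second compound built on the same core, compound 2 `C=Cc1ccc(S(=O)(=O)Nc2ccc3oc(-c4ccccc4)nc3c2)cc1`, has its aryl group and its sulfonamide placed differently. In this assay compound 2 also reaches only a limit, > 63000 nM, with no number behind it. Taken together, the shown values give (the limit of > 63000 nM in this assay, at which 2 of the 2 values shown sit), so neither compound shows measurable inhibition of the enzyme, and no size of step between them can be read from the data.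

Compound 3 `O=S(=O)(Nc1ccc(-c2nc3ccccc3o2)cc1)c1ccc(F)cc1` is the next compound, not yet measured. It differs from compound 1 in one place: 4-fluorophenyl in place of 5-chlorothiophen-2-yl on a sulfonyl sulfur. Since compound 1 stands at the limit, the step from compound 1 to compound 3 cannot be measured against a number, and nothing here suggests the change should move the value beyond the scatter. The step is therefore expected to be a step that the limit leaves unreadable from compound 1 to compound 3. For compound 3 the expected value is 100000 nM, with a range from 30000 nM to 400000 nM.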

Compound 3, half-maximal inhibitory concentration: > 63000 nM
Compound 3: no number, only a limit (the forecaster's own chance of this, stated with the estimate: 80%); the middle value lies beyond the limit too.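

In this assay compound 3 gives > 63000 nM, which is a limit and not a number. Among these compounds, compound 1 also stands at a limit, so no step from compound 1 to compound 3 can be read: the limit of > 63000 nM in this assay, at which 3 of the 3 values shown sit. The compounds shown leave open which change, if any, would bring a measurable value in this assay.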